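Amide variations on one shared core: cell toxicity notes

The source may report more compounds than this note shows. Statements on the series, on what has been measured and on what is new or still open speak of the compounds shown alone.

Measured so far in a toxicity assay on THP-1 cells (Homo sapiens) for inhibition; on this read-out lower numbers stand for higher toxicity in this test and higher numbers for lower toxicity in this test:
Compound 1, `Cn1c(-c2ccccc2)cnc1NC(=O)c1ccc(F)cc1`, gives > 100000 nM, a limit of the assay.
Compound 2, `Cc1ccccc1C(=O)Nc1ncc(-c2ccccc2)n1C`, gives > 100000 nM, also a limit.
Compound 3, `COc1ccc(-c2cnc(NC(=O)c3ccco3)n2C)cc1`, gives > 100000 nM, again a limit.

Compound 1 thus stands only at a limit in this assay, as do the other two values shown (the limit of > 100000 nM in this assay, at which 3 of the 3 values shown sit). The unmeasured compound 4, `Cn1c(-c2ccc(F)cc2)cnc1NC(=O)c1ccc(F)cc1`, differs from compound 1 by fluoro in place of hydrogen on an aromatic carbon. Among the measured compounds shown here, the one measured step, a step that the two limits leave unreadable from compound 1 to compound 2, is unreadable, both of its ends being limits; compounds 2 and 3 likewise show only limits, and no measured step touches the fluoro change. Nothing in the series therefore points to a step beyond the usual scatter in either direction. Compound 4 is expected to remain at the limit, estimated at 150000 nM with a range from 100000 nM to 300000 nM. The expected step that the limit leaves unreadable from compound 1 to compound 4 is accordingly within the scatter.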

Compound 4, half-maximal cytotoxic concentration: > 100000 nM
Compound 4: only a limit was reported (the forecaster's own chance of this, stated with the estimate: 85%); the middle value is on the limit's open side.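

Compound 4 gives > 100000 nM, again a limit. Among the compounds shown here, no step from compound 1 to compound 4 can be read, both ends being limits: the limit of > 100000 nM in this assay, at which 4 of the 4 values shown sit. The compounds shown leave open whether any change on the shared core brings toxicity to a readable value.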